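The source may hold more compounds than are shown below. What is called first, only, known or untested is meant among the compounds shown, and "the series" means these compounds.

Three analogues of the shared core have been run in a toxicity assay on THP-1 cells (Homo sapiens) for inhibition; on this read-out higher numbers stand for lower toxicity in this test and lower numbers for higher toxicity in this test. Compound 1 `Cn1c(-c2cccc([N+](=O)[O-])c2)cnc1NC(=O)c1ccc(F)cc1` reaches only a limit, > 50000 nM. Compound 2 `Cn1c(-c2cccc(C#N)c2)cnc1NC(=O)c1ccc(F)cc1` likewise reaches only a limit, > 100000 nM. Compound 3 `Cc1ccccc1-c1cnc(NC(=O)c2ccc(F)cc2)n1C` is also known only as a limit, > 50000 nM. Two of the three values stand at the limit of > 50000 nM in this assay, at which 2 of the 3 values shown sit, one at the limit of > 100000 nM in this assay, at which 1 of the 3 values shown sits. The two measured steps, a step that the two limits leave unreadable from compound 1 to compound 2 and a step that the two limits leave unreadable from compound 2 to compound 3, cannot be sized, since each end is a limit. Compound 4 `Cn1c(-c2cccc(Br)c2)cnc1NC(=O)c1ccc(F)cc1` differs from compound 3 by 3-bromophenyl in place of 2-methylphenyl on an aromatic carbon. Among the measured compounds shown here, no measured step reads in either direction, so no step beyond the scatter is expected in this assay, and a further limit is the likelier outcome. Compound 4 is expected to give 60000 nM, within 20000 nM to 200000 nM. The expected step is a step that the limit leaves unreadable from compound 3 to compound 4.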

Compound 4, half-maximal cytotoxic concentration: > 50000 nM
Compound 4 ended at the assay's limit (the forecaster's own chance of this, stated with the estimate: 80%); the middle value does not contradict the limit.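

Compound 4 stands at a limit, as do compound 1, compound 2 and compound 3, and no step among these four can be read. Still open, from the compounds shown here alone, is whether any of these aromatic substituent swaps changes the read-out in this assay.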